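The source may hold more compounds than are shown below. What is called first, only, known or untested is meant among the compounds shown, and "the series" means these compounds.

Among the compounds with values here, in a functional assay on HL-60 cells (Homo sapiens) for inhibition (a higher number here means a weaker inhibitor, a lower number a stronger inhibitor), compound 2 (`COc1cc(/C=C/c2ccc3ccccc3c2)cc(N)c1OC`) gives 3150 nM as the higher of the two numbers so far. Compound 1 (`COc1cc(/C=C\c2ccc3ccccc3c2)cc([N+](=O)[O-])c1OC`) gives 340 nM and lies lower, by a gap beyond the scatter. The next compound to consider is compound 3 (`COc1cc(/C=C\c2ccc3ccccc3c2)cc(N)c1OC`). Its difference from compound 2 is the two compounds have the same atoms and bonds and differ only in configuration as drawn: 1 of 1 stereo elements differ; a double bond is drawn E in compound 2 and Z in compound 3 and concerns configuration alone: a double bond drawn E in compound 2 is drawn Z in compound 3. Within the data shown here, no measured pair isolates this change, so any expectation rests on indirect ground. Compound 1, whose double bond is also drawn Z, reads 340 nM in this assay and offers the only hint of direction. The expected 11-fold lower number from compound 2 to compound 3 (1.02 log units; beyond the scatter) is therefore a fall beyond the scatter, towards stronger inhibition. Compound 3 is estimated at 300 nM within an expected range from 60 nM to 1500 nM.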

Compound 3, half-maximal inhibitory concentration: 330 nM
Beside the measured number, compound 3's estimate is 1.1-fold (0.04 log units) below it; measured number inside the range.
By their numbers in this assay, from the lowest: compounds 3 and 1 (each within the scatter of the next); then compound 2.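

In this assay, the configuration of the double bond now stands as a change with a measured effect: a 9.5-fold lower number from compound 2 to compound 3 (0.98 log units; beyond the scatter). This step can be assigned to configuration alone because nothing else separates the pair: the fact that compounds 2 and 3 differ only in the configuration as drawn. With the double bond drawn Z, the other new step shows amino in place of nitro on an aromatic carbon leaving the number within the scatter, a 1.0-fold lower number from compound 1 to compound 3 (0.01 log units; within the scatter), so on this evidence the configuration matters at this level while this exchange of groups does not.

From the compounds shown here alone, whether the configuration gap also holds with nitro on the aromatic carbon remains open. So does whether a hydroxyl or an acetamide in place of amino, with the double bond drawn Z, would also stay within the scatter of compound 3.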